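The compounds below may be only part of what the source reports. "The series", "measured", "known", "first", "only" and "open" are said of these compounds alone.

Compound 1 (`CC(C)[C@H](NC(=O)c1cc(Cl)ccc1OCCN)C(=O)Nc1ccc([N+](=O)[O-])cc1Cl`) is examined in a functional assay on MCF7 cells (Homo sapiens) for inhibition, read by MTT assay, with a stated time of 72 h; a lower number here means a stronger inhibitor, a higher number a weaker inhibitor. There compound 1 gives > 10000 nM, which is a limit and not a number. Compound 2 (`CC[C@@H](C)[C@H](NC(=O)c1cc(Cl)ccc1OCCN)C(=O)Nc1ccc([N+](=O)[O-])cc1Cl`) has methyl in place of hydrogen on a saturated chain carbon. Compound 2 gives > 10000 nM, which is also a limit. Within the data shown here, the only measured step is a step that the two limits leave unreadable from compound 1 to compound 2, and the evidence so far amounts to the limit of > 10000 nM in this assay, at which 2 of the 2 values shown sit.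

Compound 3 (`CC(C)[C@H](NC(=O)c1cc(Cl)ccc1OCCN)C(=O)Nc1ccc(C(F)(F)F)cc1Cl`) carries trifluoromethyl in place of nitro on an aromatic carbon, meta to a chloro group and para to a large group: trifluoromethyl in place of nitro on an aromatic carbon. Among the measured compounds shown here, no measured step touches this position, so the step from the methyl change offers no size or direction to carry over. The expectation rests on compound 1, whose limit is > 10000 nM. In this assay, no clear step in either direction is expected, and another limit is the likeliest report. The expected step is a step that the limit leaves unreadable from compound 1 to compound 3. For compound 3 the estimated value is 14000 nM, with an expected range from 4000 nM to 50000 nM.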

Compound 3, half-maximal inhibitory concentration: > 10000 nM
Compound 3 was reported as a limit; the forecaster's own chance of this, stated with the estimate: 70%; the middle value does not contradict the limit.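

In this assay, among these compounds, compound 1 and compound 3 are both reported only as limits, and no step between them can be read. The compounds shown leave open how large the change from nitro to trifluoromethyl really is, and whether any change to the shared core gives a measurable value; what stands so far is this: the limit of > 10000 nM in this assay, at which 3 of the 3 values shown sit.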